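Working notes on a short series at one receptor

The source may hold more compounds than are shown below. What is called first, only, known or untested is meant among the compounds shown, and "the series" means these compounds.

Measured so far:
compound 1 `COc1ccc(-c2cnc(N)nc2-c2ccccc2)cc1`: 56%
compound 2 `CCCCC(=O)Nc1ncc(-c2cccc(Cl)c2)c(-c2ccccc2)n1`: 52%

In an assay on CHO cells for displacement of a labelled ligand from adenosine receptor A1 (Homo sapiens), read by scintillation counting, with a stated time of 1 h, tested at 1 uM (on this read-out lower numbers stand for less inhibition and higher numbers for more inhibition at the one concentration tested (going by the name of the read-out)), compound 1 gives 56% and compound 2 gives 52%. The two numbers lie within the usual scatter of each other, so compound 2 cannot be set apart from compound 1 on these data. Compound 3 `Clc1cccc(-c2cnc(NCCCc3ccccc3)nc2-c2ccccc2)c1` differs from compound 2 in one place: 3-phenylpropyl in place of butylcarbonyl on a nitrogen on an aromatic ring. Among the measured compounds shown here, no step between measured compounds covers a change of this kind, so there is nothing to gauge it against. The expected step is a number 2 percentage points lower from compound 2 to compound 3 (within the scatter), which is no more than the scatter, in no firm direction. For compound 3 the estimate in this assay is 50%, with a range from 25% to 75%.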

Compound 3, a percentage reported as inhibition, at one concentration (the size of the read-out at that concentration, not a potency): 33%
Compound 3: the middle estimate sits 17 percentage points above what was measured; measured number inside the range.
By their numbers in this assay, from the lowest: compound 3; then compounds 2 and 1 (each within the scatter of the next).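

In this assay, among the compounds shown here, the group on a nitrogen on an aromatic ring does register: 3-phenylpropyl in place of butylcarbonyl gives a number 19 percentage points lower from compound 2 to compound 3 (beyond the scatter), the first readable step. The earlier pair, compounds 1 and 2, offered no such single-place comparison. No measurement at hand explains this step.

The step swaps the carbonyl and the aromatic ring together, so it cannot show which of them matters. From the compounds shown here alone, a butyl chain or a benzoyl group on the same nitrogen would separate the two, and how either would read remains open.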